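Hydroxy to acetyl on a fused ring core

A few compounds are considered here, and "the series" means these few. Any claim that something is new, unique, unknown or untested is made for them only; others in the source may bear on it.

Measured compounds:
Compound 1 `CC(=O)NCc1cccc(Cn2nc(NS(=O)(=O)c3ccc(Cl)s3)c3c(O)cccc32)c1`: 2.9
Compound 2 `CC(=O)NCc1cccc(Cn2nc(NS(=O)(=O)c3ccc(Cl)s3)c3c(CO)cccc32)c1`: 2.6

Compound 1 has the higher of the two numbers in a physicochemical assay for lipophilicity; a lower number here means a more polar compound, a higher number a more lipophilic compound; its nearest neighbour is compound 2, reached by a number 0.30 log units lower from compound 1 to compound 2 (within the scatter), a step that does not exceed the usual scatter. Compound 3 `CC(=O)NCc1cccc(Cn2nc(NS(=O)(=O)c3ccc(Cl)s3)c3c(C(C)=O)cccc32)c1` is the compound not yet measured. It differs from compound 1 in one place: acetyl in place of hydroxy on an aromatic carbon. Among the measured compounds shown here, only one measured step bears on this change, the exchange of hydroxy for hydroxymethyl at the same aromatic carbon, which gave a number 0.30 log units lower from compound 1 to compound 2 (within the scatter). The acetyl group is not the hydroxymethyl group, so that step is a rough guide at best; it does show that small changes at this position of the shared core of compound 1 have so far stayed within the scatter in this assay. Compound 3 is therefore expected to give a number close to that of compound 1, with a number 0.10 log units higher from compound 1 to compound 3 (within the scatter) as the expected step. The estimate for compound 3 in this assay is 3, with a range from 2.6 to 3.4.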

Compound 3, distribution coefficient: 4.8
Estimate against measurement, compound 3: 1.80 log units below, and the stated range ends below it.
By their numbers in this assay, from the lowest: compounds 2 and 1 (each within the scatter of the next); then compound 3.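

In this assay acetyl in place of hydroxy gives a number 1.90 log units higher from compound 1 to compound 3 (beyond the scatter) and acetyl in place of hydroxymethyl gives a number 2.20 log units higher from compound 2 to compound 3 (beyond the scatter) at the same aromatic carbon of the shared core. Compound 1 and compound 2 lie within the scatter of each other, so their pair gave no sign that a change at this place could produce a large step, and compound 3 now shows that it can. The change replaces a hydroxy group, counted with 1 hydrogen-bond donor and 1 heavy atom, by an acetyl group, counted with 0 hydrogen-bond donors and 3 heavy atoms, but no measurement at hand explains the size of the step, and these counts alone do not settle it.

The compounds shown leave open whether an amine or a carboxylic acid at this aromatic carbon, or a longer chain ending in a carbonyl, would stay close to compound 1 or move toward compound 3. They also leave open whether the same exchange of hydroxy for acetyl would give a step of similar size on a different core.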